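The compounds below may be only part of what the source reports. "The series", "measured", "known", "first", "only" and "open" are said of these compounds alone.

Measured compounds:
- Compound 1 `N#C[Se]c1ccc(NC(=O)OCc2ccc([N+](=O)[O-])cc2)cc1`: in a functional assay on CCRF-CEM cells (Homo sapiens) for cytotoxicity, read by MTT assay, with a stated time of 72 h (a higher number here means a weaker inhibitor of growth, a lower number a stronger inhibitor of growth), compound 1 gives 9300 nM
- Compound 2 `CCOC(=O)Nc1ccc([Se]C#N)cc1`: in this assay compound 2 gives 9800 nM

Compound 2 has the highest of the two numbers recorded in this assay, yet its nearest neighbour is compound 1, whose number is lower by a gap that stays within the usual scatter of such measurements, so the two compounds cannot be set in order against each other on these data.

Compound 3 `N#C[Se]c1ccc(NC(=O)OCc2ccccc2)cc1` has not yet been measured in this assay. It differs from compound 2 by phenyl in place of methyl on a saturated chain carbon bound to an oxygen next to a carbonyl group. For the measured compounds named here, no measured pair in this set shows this change directly, so there is no step to lean on; what can be said is that compound 1, which carries a larger group at the same position in the carbamate, and compound 2, with the smallest one, sit at indistinguishable values.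

On that basis compound 3 is expected to show no step beyond the scatter, with a 1.1-fold lower number from compound 2 to compound 3 (0.04 log units; within the scatter) as the estimated change, and its value in this assay is estimated at 9000 nM with a range from 4500 nM to 18000 nM.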

Compound 3, concentration for 50% growth inhibition: 23200 nM
Beside the measured number, compound 3's estimate is 2.6-fold (0.41 log units) below it; the whole stated range lies below it.
By their numbers in this assay, from the lowest: compounds 1 and 2 (each within the scatter of the next); then compound 3.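

In this assay the position in the carbamate proves not to be indifferent to what it carries: phenyl in place of methyl on a saturated chain carbon bound to an oxygen next to a carbonyl group gives a 2.4-fold higher number from compound 2 to compound 3 (0.37 log units; beyond the scatter) as a modest step, one that the earlier pair of compounds gave no sign of. The second step shows that the outcome also depends on what sits on the added ring, since hydrogen in place of nitro on an aromatic carbon gives a 2.5-fold higher number from compound 1 to compound 3 (0.40 log units; beyond the scatter) as a step of similar, modest size, so it is the plain phenyl, and not the nitro-bearing ring of compound 1, that stands apart here. The data offered here contain nothing that explains either step.

On these data alone, what remains open is whether other groups on that ring, such as a methoxy group or a chlorine atom, would leave the number near that of compound 3 or return it towards that of compound 1. As far as these compounds go, it is equally open whether a longer chain, such as propyl or butyl, in place of the methyl of compound 2 would already move the number, or whether only a ring does so.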